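The compounds below may be only part of what the source reports. "The series", "measured", "known", "first", "only" and "open" are said of these compounds alone.

Measured in a functional assay for inhibition, with Homo sapiens as the target; a higher number here means weaker binding, a lower number tighter binding:

- Compound 1 `O=C(O)CC/C=C\CC1COC(c2cccs2)OC1c1cccnc1`: 1000 nM
- Compound 2 `CC(C)(Oc1ccccc1F)C1OCC(C/C=C\CCC(=O)O)C(c2cccnc2)O1`: 166 nM

Of these two, compound 2 has the lower number, at 166 nM, and the gap to compound 1 lies beyond the scatter. The two compounds differ in more than one place, so this gap cannot be tied to any single structural change.

Compound 3 `Cc1ccc(SC(C)(C)C2OCC(C/C=C\CCC(=O)O)C(c3cccnc3)O2)c([N+](=O)[O-])c1` is the next to be considered. Its structural change from compound 2 is this: a group of 11 heavy atoms (7 carbon, 1 nitrogen, 2 oxygen, 1 sulfur; one six-membered aromatic ring of carbon only) in place of a group of 8 heavy atoms (6 carbon, 1 oxygen, 1 fluorine; one six-membered aromatic ring of carbon only), on a saturated chain carbon bound to two saturated chain carbons and a saturated ring carbon. The aromatic ring of carbon stays, but the group that carries it is replaced. Among the compounds with values here, no measured pair shows what a swap of this kind does in this assay, so the expectation is loose and starts from compound 2 at 166 nM. A change in either direction remains possible, with a slightly lower number only weakly favoured. The estimated step of a 1.2-fold lower number from compound 2 to compound 3 (0.07 log units; within the scatter) stays within the scatter. For compound 3 the estimated value is 140 nM, with an expected range from 40 nM to 500 nM.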

Compound 3, dissociation constant: 158 nM
Compound 3: the middle estimate sits 1.1-fold (0.05 log units) below what was measured; measured number inside the range.
By their numbers in this assay, from the lowest: compounds 3 and 2 (each within the scatter of the next); then compound 1.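

A step of a 1.1-fold lower number from compound 2 to compound 3 (0.02 log units; within the scatter) goes with the exchange of the 2-fluorophenoxy group for the group of 11 heavy atoms, on a saturated chain carbon bound to two saturated chain carbons and a saturated ring carbon. This is the first step among these compounds that differs in one place, and it shows that in this assay this position takes both groups without a difference that can be told from the scatter, although the entering group brings sulfur, nitrogen and more hydrogen-bond acceptors. Nothing at hand offers an explanation for this result.

Both groups carry a six-membered aromatic ring of carbon, so the compounds shown leave open whether such a ring is needed at this position at all, and what a group without one, such as a methoxy or an amine, would give in this assay here. They also leave open whether the sulfur or the nitrogen and oxygen atoms of the entering group could each be changed alone with as little effect on the number.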